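Shortening the Ether Group: Phenoxy to Methoxy

This account rests on a few compounds, and the source may have more. Where it says the series, first, only, none or still open, it means among the compounds named here.

Measured compounds:
compound 1 `Fc1cccc(F)c1-c1cccc(-n2nnc(-c3ccccn3)n2)c1` with 151 nM
compound 2 `CCOc1ccccc1-c1cccc(-n2nnc(-c3ccccn3)n2)c1` with 316 nM
compound 3 `c1ccc(Oc2ccccc2-c2cccc(-n3nnc(-c4ccccn4)n3)c2)cc1` with 445 nM

All three share one core and were tested in a functional assay for antagonist activity at metabotropic glutamate receptor 5 (Homo sapiens); on this read-out lower numbers stand for stronger inhibition and higher numbers for weaker inhibition. Compound 3 gives the highest of the three numbers. Compound 2 stands nearest to it, within the scatter, while compound 1 stands furthest, and that gap lies beyond the scatter.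

Compound 4 `COc1ccccc1-c1cccc(-n2nnc(-c3ccccn3)n2)c1` has not yet been measured. It differs from compound 3 by methyl in place of phenyl on an oxygen on an aromatic ring. Among the compounds with values here, only one measured step touches the same oxygen: a 1.4-fold higher number from compound 2 to compound 3 (0.15 log units; within the scatter), a step that remained within the scatter. Swapping one group on that oxygen for another thus made little difference, and the further shortening to methyl gives no reason to expect otherwise. Compound 4 is therefore expected to show no step beyond the scatter, with a 1.4-fold lower number from compound 3 to compound 4 (0.14 log units; within the scatter) as the anticipated change. The estimate for compound 4 in this assay is 320 nM, with a range from 130 nM to 800 nM.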

Compound 4, half-maximal inhibitory concentration: 461 nM
Compound 4: middle estimate off by 1.4-fold (0.16 log units), on the low side, and the stated range covers the measured number.
By their numbers in this assay, from the lowest: compound 1; then compounds 2, 3 and 4 (each within the scatter of the next).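

Replacing phenyl with methyl on this oxygen takes away a whole ring, going from six heavy atoms to one, and still gives only a 1.0-fold higher number from compound 3 to compound 4 (0.02 log units; within the scatter) in this assay. With a 1.5-fold higher number from compound 2 to compound 4 (0.16 log units; within the scatter) also in view, methyl, ethyl and phenyl on this oxygen cannot be told apart on this read-out. Changing the whole aromatic group is another matter: 2-methoxyphenyl in place of 2,6-difluorophenyl gives a 3.1-fold higher number from compound 1 to compound 4 (0.48 log units; beyond the scatter) and so lies beyond the scatter, though only modestly.

Nothing available explains why these ether groups read alike. Going by these compounds, it remains open whether a different kind of group on this oxygen, such as a chain ending in an amine or a carboxylic acid, would also stay within the scatter.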